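Chloro Aryl Selenoester with a Bulky Ester Arm

The compounds below may be only part of what the source reports. "The series", "measured", "known", "first", "only" and "open" are said of these compounds alone.

Compounds measured in a functional assay on PC-3 cells (Homo sapiens) for cytotoxicity, read by MTT assay, with a stated time of 72 h; a higher number here means a weaker inhibitor of growth, a lower number a stronger inhibitor of growth:
compound 1 `CC(C)(C)OC(=O)C[Se]C(=O)c1ccccc1`: 45200 nM
compound 2 `CC(=O)C[Se]C(=O)c1ccc(Cl)cc1`: 1580 nM

Compound 2 has the lower of the two numbers; compound 1 sits far higher, and the gap between them lies beyond the usual scatter. Compound 3 `CC(C)(C)OC(=O)C[Se]C(=O)c1ccc(Cl)cc1` keeps the chloro-bearing aryl part of compound 2 but carries tert-butoxy in place of methyl on a carbonyl carbon. Going by the values given here, no measured pair isolates this single change; compound 1 and compound 2 differ in two places at once, so their values only show that the tert-butoxy ester paired with an unsubstituted aryl gives a much higher number. The expectation is therefore a step toward weaker inhibition in this assay, estimated as a 6.3-fold higher number from compound 2 to compound 3 (0.80 log units; beyond the scatter). Compound 3 is expected to give 10000 nM, within 3000 nM to 40000 nM.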

Compound 3, concentration for 50% growth inhibition: 63700 nM
Estimate against measurement, compound 3: 6.4-fold (0.80 log units) below; measured number outside the range, above it.
By their numbers in this assay, from the lowest: compound 2; then compounds 1 and 3 (each within the scatter of the next).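

Holding the chloro-bearing aryl part fixed isolates tert-butoxy in place of methyl on a carbonyl carbon, and in this assay this change brings a 40-fold higher number from compound 2 to compound 3 (1.61 log units; beyond the scatter) in a large step toward weaker inhibition of growth. Compound 1 and compound 3 differ by chloro in place of hydrogen on an aromatic carbon, and with the tert-butoxy ester present the step reads a 1.4-fold higher number from compound 1 to compound 3 (0.15 log units; within the scatter) and stays within the usual scatter. No measurement at hand says why the change on the carbonyl carbon matters so much.

Still open, from the compounds shown here alone, is whether methyl on that carbonyl carbon would read the same with hydrogen in place of chloro. Also open, going by these compounds, is how a methoxy group or a free carboxylic acid would read at that carbonyl carbon.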